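A few compounds are considered here, and "the series" means these few. Any claim that something is new, unique, unknown or untested is made for them only; others in the source may bear on it.

The measured compounds, with their values in a functional assay on HCT-116 cells (Homo sapiens) for inhibition, read by MTT assay, with a stated time of 2 days, tested at 10 uM; a lower number here means less inhibition, a higher number more inhibition at the concentration tested (going by the name of the read-out):
Compound 1 `O=C(OCCCc1ccccc1)c1cc(-n2cc(-c3cccc(O)c3)nn2)ccc1O` gives 11%.
Compound 2 `COC(=O)c1cc(-n2cc(-c3ccc(OC)cc3)nn2)ccc1O` gives 6%.
Compound 3 `O=C(OCCCc1ccccc1)c1cc(-n2cc(-c3cc(O)ccc3O)nn2)ccc1O` gives 39%.

Compound 3 stands highest of the three in this assay; compound 1 lies nearest and compound 2 furthest, both beyond the scatter. Going by the values given here, the only step between measured compounds that differ in one place is a number 28 percentage points higher from compound 1 to compound 3 (beyond the scatter), where a hydroxy took the place of a hydrogen on an aromatic carbon.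

Compound 4 `COc1ccc(-c2cn(-c3ccc(O)c(C(=O)OCCCc4ccccc4)c3)nn2)cc1` has not yet been measured in this assay. It differs from compound 3 in one place: 4-methoxyphenyl in place of 2,5-dihydroxyphenyl on an aromatic carbon. Among the compounds with values here, no measured step covers this exact exchange. The step of a number 28 percentage points higher from compound 1 to compound 3 (beyond the scatter) bears on it, since compound 4 keeps neither hydroxy of the 2,5-dihydroxyphenyl and brings in a group without any hydrogen-bond donor. Compound 2, which also carries a 4-methoxyphenyl on the shared core though with a different ester, gives 6% in this assay. A downward step beyond the scatter is therefore expected, of about a number 29 percentage points lower from compound 3 to compound 4 (beyond the scatter). Compound 4 is estimated to give 10% in this assay, within a range from 0% to 25%.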

Compound 4, a percentage reported as inhibition, at one concentration (the size of the read-out at that concentration, not a potency): 12%
Compound 4: middle estimate off by 2 percentage points, on the low side, and the stated range covers the measured number.
By their numbers in this assay, from the lowest: compounds 2, 1 and 4 (each within the scatter of the next); then compound 3.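

In this assay, the exchange at this aromatic carbon of the five-membered ring gives a number 27 percentage points lower from compound 3 to compound 4 (beyond the scatter), so replacing 2,5-dihydroxyphenyl with 4-methoxyphenyl does not retain the higher number seen with compound 3. Among the compounds with the same ester, the other exchange gives a number 1 percentage points higher from compound 1 to compound 4 (within the scatter), so this assay does not separate 4-methoxyphenyl from 3-hydroxyphenyl at this place. Within the 4-methoxyphenyl pair, phenethyl in place of hydrogen on the ester chain gives a number 6 percentage points higher from compound 2 to compound 4 (within the scatter), so that change does not separate the two compounds either, and among the aryl groups shown only the 2,5-dihydroxyphenyl of compound 3 goes with a number beyond the scatter of the others.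

No measurement of any property of these groups is at hand to bear on this result. The compounds shown leave open whether the higher number depends on both hydroxy groups of the 2,5-dihydroxyphenyl together, and whether an aminophenyl group or a phenyl ring carrying a carboxylic acid at this aromatic carbon would match compound 3 or fall with compound 4.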